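Morpholine replaces methoxybenzylamine on the shared indole-triazole core

The compounds below may be only part of what the source reports. "The series", "measured", "known", "first", "only" and "open" are said of these compounds alone.

Compound 3 `COc1ccc(CNCc2c(-c3nnc(SC(C)C)n3-c3ccccc3)n(C)c3ccccc23)cc1` gives the highest reading of the three measured compounds in a physicochemical assay for lipophilicity (a higher number here means a more lipophilic compound, a lower number a more polar compound), at 6.27. Compound 1 `COCCNCc1c(-c2nnc(SC(C)C)n2-c2ccccc2)n(C)c2ccccc12` gives 4.36 and compound 2 `CC(C)Sc1nnc(-c2c(CNc3cnccn3)c3ccccc3n2C)n1-c1ccccc1` gives 4.22. The steps to compound 3 are both large: a number 1.91 log units higher from compound 1 to compound 3 (beyond the scatter) and a number 2.05 log units higher from compound 2 to compound 3 (beyond the scatter). Compound 4 `CC1CN(Cc2c(-c3nnc(SC(C)C)n3-c3ccccc3)n(C)c3ccccc23)CC(C)O1` differs from compound 3 by 2,6-dimethylmorpholin-4-yl in place of (4-methoxybenzyl)amino on a saturated chain carbon bound to an aromatic carbon. The step from compound 1 to compound 3, which added the aromatic ring now removed, bears most directly; the gain of two methyl groups on the saturated ring offsets part of that loss. A large downward step in this assay is therefore expected, a number 1.37 log units lower from compound 3 to compound 4 (beyond the scatter), landing near compound 1. Compound 4 is estimated at 4.9, with a range of 4.3 to 5.5.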

Compound 4, partition coefficient: 5.13
For compound 4 the middle estimate is 0.23 log units below the measured one, and the stated range covers the measured number.
By their numbers in this assay, from the lowest: compounds 2 and 1 (each within the scatter of the next); then compound 4; then compound 3.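

In this assay, 2,6-dimethylmorpholin-4-yl on this saturated chain carbon bound to an aromatic carbon falls between the amino groups (a number 1.14 log units lower from compound 3 to compound 4 (beyond the scatter)) and (a number 0.91 log units higher from compound 2 to compound 4 (beyond the scatter)) and (a number 0.77 log units higher from compound 1 to compound 4 (beyond the scatter)). High readings at this position are thus not confined to (4-methoxybenzyl)amino, the only group here with a six-membered aromatic ring of carbon only, and they also occur with a group with no hydrogen-bond donor.

Unsubstituted morpholine or piperidine in this place would separate the share of the two methyl groups from that of the ring. No evidence on the cause of these steps is available.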